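Replacing the amide side chain of compound 1

This account rests on a few compounds, and the source may have more. Where it says the series, first, only, none or still open, it means among the compounds named here.

- compound 1 `CCN(CC)CCNC(=O)c1ccc(C(CC)(CC)c2ccc(OCC(=O)C(C)(C)C)c(C)c2)n1CC`: 1600 nM
- compound 2 `C#CC(C)OC(=O)c1ccc(C(CC)(CC)c2ccc(OCC(O)C(C)(C)C)c(C)c2)n1CC`: > 50000 nM (a limit of the assay)

For the measured compounds named here, in a functional assay on Caco-2 cells (Homo sapiens), read by MTT assay, with a stated time of 48 h (on this read-out lower numbers stand for stronger inhibition and higher numbers for weaker inhibition), compound 1 gives 1600 nM, the only actual number so far. The reading for compound 2, > 50000 nM, is a limit.

Compound 3 `CCn1c(C(=O)N(C)CC(=O)O)ccc1C(CC)(CC)c1ccc(OCC(=O)C(C)(C)C)c(C)c1` keeps the core of compound 1 and carries (carboxymethyl)(methyl)amino in place of (2-(diethylamino)ethyl)amino on a carbonyl carbon. Going by the values given here, no measured step covers this change, so its size is uncertain. Weaker inhibition beyond the scatter is expected in this assay, with an estimated 7.5-fold higher number from compound 1 to compound 3 (0.88 log units; beyond the scatter). The expected value for compound 3 is 12000 nM, with an estimated range of 2500 nM to 50000 nM.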

Compound 3, half-maximal inhibitory concentration: 35900 nM
Compound 3: the middle estimate sits 3.0-fold (0.48 log units) below what was measured, within the range that was stated.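

The side chain on this carbonyl carbon clearly matters in this assay: (carboxymethyl)(methyl)amino in place of (2-(diethylamino)ethyl)amino gives a 22-fold higher number from compound 1 to compound 3 (1.35 log units; beyond the scatter). For the compounds shown here, this is the first measured step at this position, and it is a large loss of inhibition. Compound 3 still gives a real number, but it lies close to the top of the measurable range: the limit of > 50000 nM in this assay, at which 1 of the 3 values shown sits.

This single step cannot separate losing the diethylamino end from gaining the carboxylic acid or the methyl on the amide nitrogen. A plain methylamino group or a longer amine chain on the same carbonyl carbon would help separate these changes.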